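This account rests on a few compounds, and the source may have more. Where it says the series, first, only, none or still open, it means among the compounds named here.

Compound 2 `Cc1cccnc1N(C(=O)N1CCC(c2ccccc2)CC1)[C@@H]1CCCNC1` sits in an ADME assay on microsomes from liver (Homo sapiens) for metabolic stability (a higher number here means faster removal of the compound, a lower number slower removal), with a reading of < 8 mL.min-1.g-1, which is a limit of the assay and not a number. Compound 1 `O=C(N1CCC(c2ccccc2)CC1)N(c1ncccc1Cl)[C@@H]1CCCNC1` also gives only a limit, at < 9.3 mL.min-1.g-1.

Compound 3 `O=C(N1CCC(c2ccccc2)CC1)N(c1nccc2ccccc12)[C@@H]1CCCNC1` has not yet been measured. It carries isoquinolin-1-yl in place of 3-methylpyridin-2-yl on an amide-type nitrogen, and the counted difference is isoquinolin-1-yl in place of 3-methylpyridin-2-yl on an amide-type nitrogen. The entering group therefore brings an extra six-membered aromatic ring of carbon only.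

Among the compounds with values here, only one measured step bears on this change: a step that the two limits leave unreadable from compound 1 to compound 2, with methyl in place of chloro on an aromatic carbon. Its size cannot be read. It gives no measured guide to how far the new change might move the result. The change to compound 3 is also a larger structural change than that swap.

The expectation has to start from compound 2, whose limit is < 8 mL.min-1.g-1. A modest rise in this assay is expected, estimated as an at least 1.3-fold higher number from compound 2 to compound 3 (0.13 log units; that floor lies within the scatter), though with wide uncertainty. For compound 3 the estimated value is 11 mL.min-1.g-1, with an expected range from 5 mL.min-1.g-1 to 28 mL.min-1.g-1.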

Compound 3, intrinsic clearance in microsomes: 13.9 mL.min-1.g-1
The estimate for compound 3 lay 1.3-fold (0.10 log units) below the measured number, and the stated range covers the measured number.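

In this assay, compound 3 is the first compound shown that gives a true number and not a limit of the assay, so the isoquinolin-1-yl group on the amide-type nitrogen provides the first firm reading at this position. Putting isoquinolin-1-yl, with its added six-membered aromatic ring of carbon only, in place of 3-methylpyridin-2-yl gives an at least 1.7-fold higher number from compound 2 to compound 3 (0.23 log units; that floor lies within the scatter), and putting it in place of 3-chloropyridin-2-yl gives an at least 1.4-fold higher number from compound 1 to compound 3 (0.17 log units; that floor lies within the scatter), so neither floor by itself shows a change larger than repeat measurements could produce. The real size of the first step stays unknown because compound 2 gives only a limit of the assay: the limit of < 8 mL.min-1.g-1 in this assay, at which 1 of the 3 values shown sits.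

The step between the two compounds with limits cannot be read, which leaves open how methyl and chloro compare at this position. Also open, as far as these compounds go, is how this assay would respond to a different group on the amide-type nitrogen, such as a pyridine ring carrying an amine or a carboxylic acid, and whether the added carbon ring of isoquinolin-1-yl can be kept without a higher number.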